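This account rests on a few compounds, and the source may have more. Where it says the series, first, only, none or still open, it means among the compounds named here.

Working notes on the series, all read in an ADME assay on HEK-293T cells (Homo sapiens) for cytotoxicity, read by MTT assay, with a stated time of 24 h (on this read-out higher numbers stand for lower toxicity in this test and lower numbers for higher toxicity in this test), on the shared core. Compound 1 (`COC(=O)[C@@H](NC(=O)CSc1nc(-c2ccccc2)cc(-c2ccc(C)cc2)c1C#N)C(C)C`) reports only a limit, > 250000 nM, and no number. Compound 2 (`CC[C@H](C)[C@H](NC(=O)CSc1nc(-c2ccccc2)cc(-c2ccc(C)cc2)c1C#N)C(=O)OC`) gives 229000 nM in this read-out. Compound 3 (`Cc1ccc(-c2cc(-c3ccccc3)nc(SCC(=O)N[C@H](C(=O)O)C(C)C)c2C#N)cc1`) gives 250000 nM and stands within the scatter of compound 2. That pair is a 1.1-fold higher number from compound 2 to compound 3 (0.04 log units; within the scatter). The other two steps add little: an at least 1.0-fold lower number from compound 1 to compound 2 (0.03 log units; that floor lies within the scatter), and a number no higher from compound 1 to compound 3 (the limit leaves the size open).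

Compound 4 (`COC(=O)C[C@H](NC(=O)[C@@H](NC(=O)CSc1nc(-c2ccccc2)cc(-c2ccc(C)cc2)c1C#N)C(C)C)C(=O)OC`) carries (1,2-bis(methoxycarbonyl)ethyl)amino in place of hydroxy on a carbonyl carbon, counted as (1,2-bis(methoxycarbonyl)ethyl)amino in place of hydroxy on a carbonyl carbon. Within the data shown here, no measured compound carries this group, so the three compounds give only indirect guidance. Among the measured compounds shown here, no measured step of readable size lies beyond the scatter, and the step from compound 1 to compound 3 has no readable size. For the measured compounds named here, a step beyond the scatter is therefore not expected, because a 1.1-fold higher number from compound 2 to compound 3 (0.04 log units; within the scatter) is the only fully numerical step between two measured values. The estimate means a 1.1-fold lower number from compound 3 to compound 4 (0.06 log units; within the scatter), and this expected step stays within the scatter. For compound 4 the expected value is 220000 nM, with an estimated range from 120000 nM to 320000 nM.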

Compound 4, half-maximal cytotoxic concentration: > 250000 nM
Compound 4 ended at the assay's limit (the forecaster's own chance of this, stated with the estimate: 40%); middle value at least 1.1-fold (0.05 log units) from the limit.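

In this assay compound 4 reports only a limit, > 250000 nM, and no number. On a carbonyl carbon whose other neighbour is a saturated chain carbon, (1,2-bis(methoxycarbonyl)ethyl)amino in place of hydroxy gives a number no lower from compound 3 to compound 4 (the limit leaves the size open), so this position accepts the entering group of 11 heavy atoms without a reading that falls below the value of the acid in this test. The sizes of the steps ending at compound 4 cannot be read, because the values involved stop at the limit: the limit of > 250000 nM in this assay, at which 2 of the 4 values shown sit.

From the compounds shown here alone, whether a simple amine or a single amino acid methyl ester in place of hydroxy on this carbonyl carbon would give a full number in this read-out stays open, as does the effect of free carboxylic acid groups in place of the two methoxycarbonyl groups of compound 4. Which change on the shared core would move the read-out beyond the scatter also stays open.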